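Swapping Benzyl for Cyclohexyl on a Urea Nitrogen

This account rests on a few compounds, and the source may have more. Where it says the series, first, only, none or still open, it means among the compounds named here.

Compound 1, `Cc1nc(N)sc1CCCN/C(N)=N/C(=O)N[C@@H](C)c1ccccc1`, gives 51.3 nM in an assay on membranes from Sf9 cells for displacement of a labelled ligand from histamine H2 receptor (Homo sapiens), read by scintillation counting, with a stated time of 60 min; a higher number here means a weaker inhibitor, a lower number a stronger inhibitor.
Compound 2, `Cc1nc(N)sc1CCCN/C(N)=N/C(=O)NCc1ccco1`, gives 10.5 nM in this assay.
Compound 3, `Cc1nc(N)sc1CCCN/C(N)=N/C(=O)NCc1ccccc1`, gives 69.2 nM in this assay.

Compound 3 carries the highest number of the three. Its gap to compound 1 is small, a 1.3-fold higher number from compound 1 to compound 3 (0.13 log units; within the scatter), and lies within the scatter; its gap to compound 2 is larger, a 6.6-fold higher number from compound 2 to compound 3 (0.82 log units; beyond the scatter), and lies beyond it.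

Compound 4, `Cc1nc(N)sc1CCCN/C(N)=N/C(=O)NC1CCCCC1`, differs from compound 3 by cyclohexyl in place of benzyl on an amide-type nitrogen. Among the compounds with values here, two measured steps touch this position. The exchange of one ring for another, a 6.6-fold higher number from compound 2 to compound 3 (0.82 log units; beyond the scatter), moved the number modestly; the removal of a methyl on the chain carbon, a 1.3-fold higher number from compound 1 to compound 3 (0.13 log units; within the scatter), changed nothing beyond the scatter. As far as these compounds go, neither step trades an aromatic ring for a saturated one, so the direction of this change remains open. The expectation for compound 4 is therefore a step of a 1.0-fold higher number from compound 3 to compound 4 (0.00 log units; within the scatter) in this assay, not clearly beyond the scatter. Compound 4 is estimated at 70 nM, within a range from 20 nM to 250 nM.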

Compound 4, inhibition constant: 170 nM
Beside the measured number, compound 4's estimate is 2.4-fold (0.39 log units) below it, within the range that was stated.
By their numbers in this assay, from the lowest: compound 2; then compounds 1 and 3 (each within the scatter of the next); then compound 4.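

Cyclohexyl in place of benzyl on this amide-type nitrogen is the first change here from an aromatic ring to a saturated one, and in this assay it raises the number modestly (a 2.5-fold higher number from compound 3 to compound 4 (0.39 log units; beyond the scatter)). Compound 4 also stands beyond the scatter from the other two compounds (a 3.3-fold higher number from compound 1 to compound 4 (0.52 log units; beyond the scatter); a 16-fold higher number from compound 2 to compound 4 (1.21 log units; beyond the scatter)), which makes it the weakest of the four in this assay, with the largest gap to the furan-2-yl compound. No measurement available gives a reason for this shift.

Benzyl and cyclohexyl differ both in the ring and in the chain carbon that benzyl carries, so these compounds cannot separate those two parts of the change. A cyclohexylmethyl group on the same nitrogen would keep that chain carbon while carrying the saturated ring.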